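Chloro at the phenyl: a step repeated on a second core

The compounds below may be only part of what the source reports. "The series", "measured", "known", "first", "only" and "open" are said of these compounds alone.

Compound 1 `CCC(C)Sc1nc2c(cc(-c3ccccc3)n2-c2ccccc2)c(=N)s1` is measured in a functional assay on the whole organism for inhibition, with Rattus norvegicus as the target, read by ELISA, with stated times of 30 min and 6 h, at a dose of 30 mg/kg by the oral route (a lower number here means less inhibition, a higher number more inhibition at the dose given (going by the name of the read-out)), and gives 50%. Compound 2 `CCC(C)Sc1nc2c(cc(-c3ccc(Cl)cc3)n2-c2ccccc2)c(=N)s1` differs from compound 1 by chloro in place of hydrogen on an aromatic carbon, and in this assay compound 2 gives 2%, so a number 48 percentage points lower from compound 1 to compound 2 (beyond the scatter). Compound 3 `N=c1c2cc(-c3ccccc3)n(-c3ccccc3)c2[nH]c(=S)n1N` has a different core, and how the two cores differ is not broken down here; in this assay compound 3 gives 23%, a number that lies between those of compound 1 and compound 2. Compound 4 `N=c1c2cc(-c3ccc(Cl)cc3)n(-c3ccccc3)c2[nH]c(=S)n1N` has not been measured. It differs from compound 3 by chloro in place of hydrogen on an aromatic carbon, the same change as that between compound 1 and compound 2, made at the same place. Because a number 48 percentage points lower from compound 1 to compound 2 (beyond the scatter), and because compound 3 starts at 23%, a large drop is expected, a number 18 percentage points lower from compound 3 to compound 4 (beyond the scatter). Among the measured compounds shown here, the estimate for compound 4 in this assay is 5%, with a range from 0% to 20%; the one earlier step is the only basis for it.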

Compound 4, a percentage reported as inhibition, in the whole organism at one dose (the size of the read-out at that dose, not a potency): 0%
The estimate for compound 4 lay 5 percentage points above the measured number; the range from low to high includes it.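

In this assay the chloro change again lowers the number on the second core, a number 23 percentage points lower from compound 3 to compound 4 (beyond the scatter), so the direction of the step carries over from one core to the other. The size of the step does not carry over: the same change on two cores in this assay, a number 48 percentage points lower (beyond the scatter) from compound 1 to compound 2 and a number 23 percentage points lower (beyond the scatter) from compound 3 to compound 4, 25 percentage points apart, beyond the scatter of two such steps This does not show that the gap in size belongs to the core rather than to the lower starting number of compound 3 at 23%, and two pairs say nothing about any further core.

The compounds shown carry only hydrogen or chloro at this place, so whether a fluoro, a methoxy or an amine there would also lower the number stays open. Going by these compounds, whether the steps would hold at another dose also stays open.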